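Phenol ether variation at the aryl oxygen

The source may hold more compounds than are shown below. What is called first, only, known or untested is meant among the compounds shown, and "the series" means these compounds.

Measured compounds:
compound 1 `COc1ccc(C(c2cc3cc(Cl)ccc3o2)n2cncn2)cc1`: > 1000 nM
compound 2 `Oc1ccc(C(c2cc3cc(Cl)ccc3o2)n2cncn2)cc1`: 30.3 nM

In an assay on JEG-3 cells for inhibition of Aromatase (Homo sapiens), with a stated time of 1 h (a higher number here means a weaker inhibitor, a lower number a stronger inhibitor), compound 1 reaches only a limit, > 1000 nM. In this assay, among the measured compounds shown here, compound 2 gives 30.3 nM, the only number among the two measured compounds. The value of compound 1, by contrast, is a limit. For the measured compounds named here, the one measured step at this oxygen, an at least 33-fold lower number from compound 1 to compound 2 (1.51 log units; beyond the scatter), is bounded by the limit (the limit of > 1000 nM in this assay, at which 1 of the 2 values shown sits).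

Compound 3 `CCC#CCOc1ccc(C(c2cc3cc(Cl)ccc3o2)n2cncn2)cc1` carries the change (pent-2-yn-1-yl in place of hydrogen on an oxygen on an aromatic ring). Because the measured step of an at least 33-fold lower number from compound 1 to compound 2 (1.51 log units; beyond the scatter) runs the other way, the larger ether in compound 3 is expected to raise the number in this assay by a 26-fold higher number from compound 2 to compound 3 (1.42 log units; beyond the scatter). Compound 3 is therefore estimated at 800 nM in this assay, with a range of 100 nM to 6000 nM, and a limit rather than a number is plausible.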

Compound 3, half-maximal inhibitory concentration: > 1000 nM
Compound 3: only a limit was reported (the forecaster's own chance of this, stated with the estimate: 45%); middle value at least 1.2-fold (0.09 log units) away from the limit.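

In this assay compound 3 gives > 1000 nM and this is a limit. Pent-2-yn-1-yl in place of hydrogen on the oxygen gives an at least 33-fold higher number from compound 2 to compound 3 (1.51 log units; beyond the scatter) and so a second ether, with a longer chain than methyl, also ends at the limit, leaving the free hydroxy of compound 2 as the only group here with a readable number. The step from compound 1 to compound 3 cannot be read, and both ethers stay unranked: the limit of > 1000 nM in this assay, at which 2 of the 3 values shown sit.

As far as these compounds go, how far either ether lies past the limit stays open. Also open, from the compounds shown here alone, is whether an amine or a carboxylic acid in place of the hydroxy would keep a number near that of compound 2.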